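The source may hold more compounds than are shown below. What is called first, only, known or untested is meant among the compounds shown, and "the series" means these compounds.

Of the compounds shown here, two sharing one core have been measured so far. In a functional assay on MIA PaCa-2 cells (Homo sapiens) for antiproliferative activity (on this read-out lower numbers stand for an effect already at smaller amounts and higher numbers for an effect only at larger amounts of compound), compound 1 (`C#CCNC(=O)c1cccc2c1cc(C)n2-c1nc2c(c(NCc3ccccc3)n1)COCC2`) gives 1080 nM and compound 2 (`C#CC(=O)Nc1cccc2c1cc(C)n2-c1nc2c(c(NCc3ccccc3)n1)COCC2`) gives 78.7 nM as the lower of the two numbers, so compound 2 stands at the favourable end of this very small set. The next molecule, compound 3 (`C=CC(=O)Nc1cccc2c1cc(C)n2-c1nc2c(c(NCc3ccccc3)n1)COCC2`), alters compound 2 in a single place (vinyl in place of ethynyl on a carbonyl carbon), with vinyl in place of ethynyl on a carbonyl carbon.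

For the measured compounds named here, the one measured step that bears on this is a 14-fold lower number from compound 1 to compound 2 (1.14 log units; beyond the scatter) and it was large. It came with (ethynylcarbonyl)amino in place of propargylcarbamoyl on an aromatic carbon, so it shows that this part of the molecule can matter. Going by the values given here, that exchange was broader than the new one, however, and no measured pair compares ethynyl with vinyl directly. A much smaller change is therefore expected, and the estimate is a 1.3-fold higher number from compound 2 to compound 3 (0.10 log units; within the scatter) with no firm direction. For compound 3 the estimated value is 100 nM and a range from 30 nM to 350 nM is expected.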

Compound 3, half-maximal effective concentration in the MIA PaCa-2 assay: 880 nM
The estimate for compound 3 lay 8.8-fold (0.94 log units) below the measured number; measured number outside the range, above it.
By their numbers in the MIA PaCa-2 assay, from the lowest: compound 2; then compounds 3 and 1 (each within the scatter of the next).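

In the MIA PaCa-2 assay, the exchange on the carbonyl carbon alone gives an 11-fold higher number from compound 2 to compound 3 (1.05 log units; beyond the scatter), so two groups with the same count of heavy atoms, differing in a triple or a double bond, are far from interchangeable here. The second new step, a 1.2-fold lower number from compound 1 to compound 3 (0.09 log units; within the scatter), shows that the (vinylcarbonyl)amino group cannot be told apart from propargylcarbamoyl on this read-out, so the low number of compound 2 depends on the ethynyl group and not on the (vinylcarbonyl)amino-type amide link alone. In a physicochemical assay for pharmacokinetics, read by LC-MS, in phosphate buffer, tested at 1 uM (a lower number here means that the compound disappears faster, a higher number that the compound lasts longer), compound 2 gives 0.21 h and compound 3 gives 4.31 h. In the physicochemical assay, the same exchange also separates the two compounds strongly, with the compound that acts at smaller amounts in cells being the one that disappears faster in phosphate buffer, and with only this one pair a link between the two results stays a possibility: the measured half-life of compound 2, 0.21 h, and of compound 3, 4.31 h, a 21-fold higher number (1.31 log units; beyond the scatter)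

The compounds shown leave open how an ethyl group or a propynyl group on the same carbonyl carbon would behave on either read-out. They also leave open whether a short half-life in buffer goes with a low number in cells beyond compound 2 and compound 3.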